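This account rests on a few compounds, and the source may have more. Where it says the series, first, only, none or still open, it means among the compounds named here.

Series notes on the shared core. Compound 1 `Clc1ccc([C@@H]2C[C@@H]3Cc4ccc5ccccc5c4N2O3)cc1` and compound 2 `COc1cccc([C@@H]2C[C@@H]3Cc4ccc5ccccc5c4N2O3)c1` differ only in the group on a saturated ring carbon. In an ADME assay on THP-1 cells (Homo sapiens) for cytotoxicity, read by MTT assay, with a stated time of 72 h (a lower number here means that less compound is tolerated, a higher number that more compound is tolerated), compound 1 gives no number, only a limit of the assay, > 300000 nM. In this assay compound 2 likewise gives only a limit, > 300000 nM. The step that the two limits leave unreadable from compound 1 to compound 2 therefore cannot be sized, since both values sit at the limit of > 300000 nM in this assay, at which 2 of the 2 values shown sit. Compound 2 thus stands at the limit in this assay, with no measured number to place it against anything else. Compound 3 `Clc1ccc([C@@H]2C[C@@H]3Cc4ccc5ccccc5c4N2O3)c(Cl)c1` is not yet measured and differs from compound 2 by 2,4-dichlorophenyl in place of 3-methoxyphenyl on a saturated ring carbon. Going by the values given here, the only measured step that bears on this change is a step that the two limits leave unreadable from compound 1 to compound 2, and it is unreadable, so neither a direction nor a size can be drawn from it. Compound 3 is expected to remain at the limit in this assay, an expected step of a number no higher from compound 2 to compound 3 (the limit leaves the size open). The estimate for compound 3 in this assay is 300000 nM, with a range from 100000 nM to 1000000 nM.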

Compound 3, half-maximal cytotoxic concentration: > 250000 nM
Compound 3 was reported as a limit; the forecaster's own chance of this, stated with the estimate: 75%; the middle value lies beyond the limit too.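

In this assay compound 3 gives only a limit of the assay, > 250000 nM. Going by these compounds alone, with compound 1 and compound 2 also at limits, no step among the three can be read. Open, from the compounds shown here alone, is whether changing the group on the saturated ring carbon alters tolerated concentration at all.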